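Extending the Ether Chain of Compound 1

The compounds below may be only part of what the source reports. "The series", "measured", "known", "first", "only" and "open" are said of these compounds alone.

Compound 1 `COc1cc(NC(=O)c2cnc(C)cn2)c2ncccc2c1` — 270 nM
Compound 2 `COc1cc(NC(=O)c2cnccn2)c2ncccc2c1` — 470 nM

In a functional assay on MIA PaCa-2 cells (Homo sapiens) for inhibition, read by MTT assay, with a stated time of 72 h (a higher number here means a weaker inhibitor, a lower number a stronger inhibitor), compound 1 gives 270 nM, the lowest of the two numbers recorded. Compound 2 gives 470 nM, and the step of a 1.7-fold higher number from compound 1 to compound 2 (0.24 log units; within the scatter) lies within the scatter. Compound 3 `Cc1cnc(C(=O)Nc2cc(OCCN)cc3cccnc23)cn1` differs from compound 1 by aminomethyl in place of hydrogen on a saturated chain carbon bound to an oxygen on an aromatic ring. Within the data shown here, the only measured step, a 1.7-fold higher number from compound 1 to compound 2 (0.24 log units; within the scatter), concerns a different position and does not bear on this chain change, so there is no measured guide. The expected step is therefore a 1.1-fold higher number from compound 1 to compound 3 (0.05 log units; within the scatter), none beyond the scatter, though with wide uncertainty. Compound 3 is expected to give 300 nM, with a range from 100 nM to 1000 nM.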

Compound 3, half-maximal inhibitory concentration: > 10000 nM
Compound 3 ended at the assay's limit; the forecaster's own chance of this, stated with the estimate: 5%; middle value at least 33-fold (1.52 log units) away from the limit.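

Going from methoxy to 2-aminoethoxy gives an at least 37-fold higher number from compound 1 to compound 3 (1.56 log units; beyond the scatter) in this assay, so this position responds strongly to the change, whereas the only earlier step, at another position, stayed within the scatter. The value of compound 3 is a limit of the assay and not a number: the limit of > 10000 nM in this assay, at which 1 of the 3 values shown sits. The compounds shown leave open whether the amine or the longer chain goes with this loss; an ethoxy or 2-hydroxyethoxy group at this place would separate the two.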